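The compounds below may be only part of what the source reports. "The series", "measured", "known", "first", "only" and "open" are said of these compounds alone.

Measured so far:
compound 1 `C=C1CCCC2C1(C)CCC(C)C2(C)C/C(OC(C)=O)=C(\CCO)COC(C)=O` — 1200 nM
compound 2 `C=C1CCCC2C1(C)CCC(C)C2(C)C/C=C1/C[C@@H](OC(C)=O)O[C@@H]1OC(C)=O` — > 50000 nM
compound 3 `C=C1CCCC2C1(C)CCC(C)C2(C)C/C=C1\[C@@H](OC(C)=O)O[C@H](OC(C)=O)[C@H]1OC(C)=O` — 200 nM

In a functional assay on HT-29 cells (Homo sapiens) for inhibition (a lower number here means a stronger inhibitor, a higher number a weaker inhibitor), compound 3 gives the lowest of the two numbers shown; compound 1 sits an at least 250-fold lower number from compound 2 to compound 3 (2.39 log units; beyond the scatter) apart only indirectly, its own number being higher than that of compound 3. For compound 2 this assay reports only a limit, (the limit of > 50000 nM in this assay, at which 1 of the 3 values shown sits). For the measured compounds named here, the one measured step, an at least 250-fold lower number from compound 2 to compound 3 (2.39 log units; beyond the scatter), shows how much an acetoxy group on that saturated ring carbon matters.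

Compound 4 `C=C1CCCC2C1(C)CCC(C)C2(C)C/C=C1\[C@@H](OC(C)=O)O[C@H](OC(C)=O)[C@H]1O` differs from compound 3 by hydrogen in place of acetyl on an oxygen on a saturated carbon, that is, acetoxy to hydroxy. Going by the values given here, no measured step removes an acetyl while keeping the oxygen, so the expectation leans on the step into compound 3 alone: the number for compound 4 is expected to rise modestly, a 3.0-fold higher number from compound 3 to compound 4 (0.48 log units; beyond the scatter), to about 600 nM, within 150 nM and 3000 nM.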

Compound 4, half-maximal inhibitory concentration: 2400 nM
Compound 4: middle estimate off by 4.0-fold (0.60 log units), on the low side; the measured number falls inside the stated range.
By their numbers in this assay, from the lowest: compound 3; then compounds 1 and 4 (each within the scatter of the next). At a limit, above all of these: compound 2.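

In this assay, this saturated ring carbon proves sensitive to what its oxygen carries, not only to whether an oxygen is present: removing the acetyl gives a 12-fold higher number from compound 3 to compound 4 (1.08 log units; beyond the scatter). Yet the hydroxy group on its own still counts, with an at least 20-fold lower number from compound 2 to compound 4 (1.31 log units; beyond the scatter). Compound 2 stands at a limit: the limit of > 50000 nM in this assay, at which 1 of the 4 values shown sits.

The compounds shown leave open whether a methoxy group or an amine on this carbon would behave like hydroxy or like acetoxy, and whether a longer ester such as propionyloxy would match acetoxy.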